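A Bromine Enters the Furan of Compound 3

The compounds below may be only part of what the source reports. "The series", "measured", "known", "first", "only" and "open" are said of these compounds alone.

Compound 1, `N#C/C(=C\c1ccc(Cl)cc1)C(=O)c1ccc[nH]1`: 48000 nM
Compound 2, `N#C/C(=C\c1ccc([N+](=O)[O-])cc1)C(=O)c1c[nH]c2ccccc12`: 46000 nM
Compound 3, `COc1ccc(CNC(=O)/C(C#N)=C/c2ccco2)cc1`: 34000 nM

All three measured compounds were tested in a functional assay on MIA cells (Homo sapiens) for inhibition, read by MTT assay, with a stated time of 72 h; a lower number here means a stronger inhibitor of growth, a higher number a weaker inhibitor of growth. Compound 3 shows the lowest of the three numbers, but its distance to compound 2 and its distance to compound 1 both fall within the usual scatter of such measurements, so the three cannot be separated from one another on these data, and compound 3 cannot be called the strongest of them.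

Compound 4, `COc1ccc(CNC(=O)/C(C#N)=C/c2ccc(Br)o2)cc1`, differs from compound 3 in a single change: bromo in place of hydrogen on an aromatic carbon. For the measured compounds named here, no pair of measured compounds differs by a change of this kind, so there is no measured step to lean on. The expectation is therefore a modest one: a step in this assay that stays close to the scatter, leaning, if anywhere, toward a somewhat lower number, without a firm reason in the data for either direction. Compound 4 is expected to give about 25000 nM in this assay, with a plausible range from 8000 nM to 70000 nM. The step this estimate implies is a 1.4-fold lower number from compound 3 to compound 4 (0.13 log units; within the scatter), which should be read as a guess rather than a prediction.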

Compound 4, concentration for 50% growth inhibition: 16000 nM
Estimate against measurement, compound 4: 1.6-fold (0.19 log units) above; measured number inside the range.
By their numbers in this assay, from the lowest: compound 4; then compounds 3, 2 and 1 (each within the scatter of the next).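

The change from furan-2-yl to 5-bromofuran-2-yl gives a 2.1-fold lower number from compound 3 to compound 4 (0.33 log units; beyond the scatter) in this assay, so this one position, on the aromatic carbon next to the ring oxygen and two ring bonds from the ring atom that bears a large group, can move the number by a modest step beyond the scatter. For the compounds shown here, the earlier compounds could not show this, since no two of them differ in one place and their numbers could not be separated from one another; this pair is the only single-place comparison in the set, and it covers one change on one background. Nothing measured here speaks to why the number falls with bromo at this position, and the step stands without an explanation.

The compounds shown leave open whether chlorine, a methyl group or an amine at this same place would move the number as bromo does, or in the opposite direction. They also leave open whether the step would persist on another background, for instance with a carboxylic acid in place of the methoxy group of compound 4.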